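This account rests on a few compounds, and the source may have more. Where it says the series, first, only, none or still open, it means among the compounds named here.

Measured in a functional assay on CHO-K1 cells for antagonist activity at C-X-C chemokine receptor type 3 (Homo sapiens), read by FLIPR, with a stated time of 10 min, in the presence of a further agent that is not named here; on this read-out higher numbers stand for weaker inhibition and lower numbers for stronger inhibition:
compound 1 `C[C@@H]1CN(c2sc(C(F)(F)F)nc2-c2nc3cc(OCCO)ccc3[nH]2)CCN1C(=O)Cn1cnc2cccnc21` gives 2.1 nM
compound 2 `C[C@@H]1CN(c2sc(C(F)(F)F)nc2-c2nc3ccccc3[nH]2)CCN1C(=O)Cn1cccn1` gives 13 nM
compound 3 `Cc1nc(C)n(CC(=O)N2CCN(c3sc(C(F)(F)F)nc3-c3nc4cccc(C)c4[nH]3)C[C@H]2C)n1` gives 3.1 nM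

Of these three, compound 2 has the highest number, so the weakest inhibition, and both compound 3 and compound 1 sit lower by more than the scatter. Compound 4 `C[C@@H]1CN(c2sc(C(F)(F)F)nc2-c2nc3ccccc3[nH]2)CCN1C(=O)Cn1ccc(C(=O)O)n1` has not yet been measured. It differs from compound 2 in one place: carboxy in place of hydrogen on an aromatic carbon, so that the 1H-pyrazol-1-yl of compound 2 becomes 3-carboxy-1H-pyrazol-1-yl. Going by the values given here, no measured pair shows this change, so there is no step to lean on. The step of a 1.2-fold higher number from compound 2 to compound 4 (0.09 log units; within the scatter) is expected to be small, none beyond the scatter, with a slight lean toward a higher number. Compound 4 is therefore estimated at 16 nM, within a range from 4 nM to 65 nM.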

Compound 4, half-maximal inhibitory concentration: 2100 nM
Compound 4: middle estimate off by 130-fold (2.12 log units), on the low side, and the stated range ends below it.
By their numbers in this assay, from the lowest: compounds 1 and 3 (each within the scatter of the next); then compound 2; then compound 4.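

In this assay, carboxy in place of hydrogen on this aromatic carbon of the 1H-pyrazol-1-yl group gives a 160-fold higher number from compound 2 to compound 4 (2.21 log units; beyond the scatter), which means much weaker inhibition. Going by these compounds alone, this carbon is therefore far from indifferent to what it carries, something the earlier compounds, with no one-place step among them, could not show. Nothing measured here explains the size of this step. Going by these compounds, it remains open whether the step belongs to the carboxy itself or to any group on this carbon. A methyl ester, a primary amide or a methyl group there would help separate the two.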